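Acetamido to ureido: cytotoxicity expected from compound 2

This account rests on a few compounds, and the source may have more. Where it says the series, first, only, none or still open, it means among the compounds named here.

Measured compounds in a functional assay on MT4 cells (Homo sapiens) (a higher number here means that more compound is tolerated, a lower number that less compound is tolerated), are these
- compound 1 `Cc1cn([C@@H]2O[C@H](CO[Si](C)(C)C(C)(C)C)[C@@]3(OS(=O)(=O)C=C3NCC(=O)O)[C@H]2O[Si](C)(C)C(C)(C)C)c(=O)n(C)c1=O` gives 30000 nM as a number
- compound 2 `CC(=O)NC1=CS(=O)(=O)O[C@@]12[C@@H](CO[Si](C)(C)C(C)(C)C)O[C@@H](n1cc(C)c(=O)n(C)c1=O)[C@@H]2O[Si](C)(C)C(C)(C)C` gives 10700 nM as a number
- compound 3 `Cc1cn([C@@H]2O[C@@H]3COC(=O)[C@]3(OS(C)(=O)=O)[C@H]2O)c(=O)[nH]c1=O` gives >= 250000 nM as a limit, not a number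

Within the data shown here, compound 2 holds the lower of the two numbers so far, and compound 1 is its nearest neighbour. Compound 3 reports only a limit (>= 250000 nM) and so cannot be ranked by number.

The change under study leads from compound 2 to compound 4 `Cc1cn([C@@H]2O[C@H](CO[Si](C)(C)C(C)(C)C)[C@@]3(OS(=O)(=O)C=C3NC(N)=O)[C@H]2O[Si](C)(C)C(C)(C)C)c(=O)n(C)c1=O` and is amino in place of methyl on a carbonyl carbon in short amino in place of methyl on a carbonyl carbon, or acetyl to carbamoyl. Among the measured compounds shown here, one measured step bears on it, with acetyl in place of carboxymethyl on an amine nitrogen (a 2.8-fold lower number from compound 1 to compound 2 (0.45 log units; beyond the scatter)), which is modest but beyond the scatter. Compound 3 differs from compound 2 in too many places to serve as a guide. With a single modest step as precedent, a small change in this assay is expected, leaning slightly towards a higher number and possibly lost in the scatter. The expected move is a 1.3-fold higher number from compound 2 to compound 4 (0.12 log units; within the scatter) on this estimate. Compound 4 is estimated at 14000 nM with an expected range from 6000 nM to 35000 nM for repeat measurements.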

Compound 4, half-maximal cytotoxic concentration: 3700 nM
The estimate for compound 4 lay 3.8-fold (0.58 log units) above the measured number, and the stated range ends above it.
By their numbers in this assay, from the lowest: compound 4; then compound 2; then compound 1. At a limit, above all of these: compound 3.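

In this assay, among these compounds, the group on the amine nitrogen moves the number further than the single earlier step could show: amino in place of methyl on a carbonyl carbon gives a 2.9-fold lower number from compound 2 to compound 4 (0.46 log units; beyond the scatter) and so continues the direction of a 2.8-fold lower number from compound 1 to compound 2 (0.45 log units; beyond the scatter) instead of reversing it. Across the three compounds that vary at this nitrogen, the carboxymethyl, acetyl and carbamoyl groups fall in one order with none going against it, and the full span is an 8.1-fold lower number from compound 1 to compound 4 (0.91 log units; beyond the scatter) on an otherwise unchanged core. Exchanging a single heavy atom at the carbonyl carbon, with the gain of one hydrogen-bond donor, is therefore enough to shift tolerance beyond the scatter, and nothing measured here gives a reason for the shift.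

From the compounds shown here alone, whether this order extends beyond three groups remains open, for example with a free amine, a methanesulfonyl group, a longer acyl chain or a methyl-substituted urea on the same nitrogen. Also open, going by these compounds, is whether the acetamido to ureido change has a similar effect on a core without the tert-butyldimethylsilyl groups.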